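The source may hold more compounds than are shown below. What is called first, only, known or untested is meant among the compounds shown, and "the series" means these compounds.

Of the compounds shown here, three sharing one core have been tested in a functional assay on A549 cells (Homo sapiens) for antiproliferative activity, read by MTT assay, with a stated time of 72 h; a higher number here means a weaker inhibitor, a lower number a stronger inhibitor. Compound 1 `COc1cc2ncnc(Nc3ccc(Cl)c(C(F)(F)F)c3)c2cc1OCCCCC(=O)Nc1ccc(S(N)(=O)=O)cc1` carries a 4-chloro-3-(trifluoromethyl)phenyl group on the nitrogen attached to the core, and in this assay compound 1 gives 9270 nM. Compound 2 `COc1cc2ncnc(Nc3cccc(F)c3)c2cc1OCCCCC(=O)Nc1ccc(S(N)(=O)=O)cc1` carries a 3-fluorophenyl group there, and in this assay compound 2 reaches only the limit of the assay, > 40000 nM, not a number. Compound 3 `COc1cc2ncnc(Nc3ccc(Br)cc3)c2cc1OCCCCC(=O)Nc1ccc(S(N)(=O)=O)cc1` carries a 4-bromophenyl group, and in this assay compound 3 likewise stands at the limit of the assay, > 40000 nM. Compound 3 is thus among the weaker entries: the steps of an at least 4.3-fold higher number from compound 1 to compound 2 (0.63 log units; beyond the scatter) and an at least 4.3-fold higher number from compound 1 to compound 3 (0.63 log units; beyond the scatter) both run away from compound 1, while a step that the two limits leave unreadable from compound 2 to compound 3 cannot be sized due to the limit of > 40000 nM in this assay, at which 2 of the 3 values shown sit.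

Compound 4 `COc1ccc(Nc2ncnc3cc(OC)c(OCCCCC(=O)Nc4ccc(S(N)(=O)=O)cc4)cc23)cc1OC` has not yet been measured; it differs from compound 3 by 3,4-dimethoxyphenyl in place of 4-bromophenyl on a nitrogen on an aromatic ring. The two readable steps show that exchanging the group on this nitrogen can move the result beyond the scatter, yet neither involves a dimethoxy group, so the direction for compound 4 is open. The step of an at least 1.3-fold lower number from compound 3 to compound 4 (0.12 log units; that floor lies within the scatter) is expected to be modest at most. Compound 4 is estimated at 30000 nM, within 8000 nM to 100000 nM, with a real chance that only a limit is reported again.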

Compound 4, half-maximal inhibitory concentration: > 40000 nM
Compound 4: a limit, no number; the forecaster's own chance of this, stated with the estimate: 55%; middle value at least 1.3-fold (0.12 log units) away from the limit.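

Compound 4 shows that the 3,4-dimethoxyphenyl group joins 3-fluorophenyl and 4-bromophenyl on this nitrogen: in this assay compound 4 is also only a limit, not a number. The one readable new step is an at least 4.3-fold higher number from compound 1 to compound 4 (0.63 log units; beyond the scatter), so of the four groups shown, only 4-chloro-3-(trifluoromethyl)phenyl gives a number. The steps among compound 2, compound 3 and compound 4 cannot be read, and no order among their groups can be given, due to a shared ceiling: the limit of > 40000 nM in this assay, at which 3 of the 4 values shown sit.

The compounds shown leave open whether the number for compound 1 depends on the chloro group, the trifluoromethyl group or both, which a phenyl ring carrying only one of them could separate. They also leave open how an amine or a carboxylic acid on this ring, or a longer chain in the linker, would read.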